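Nitro-substituted thiosemicarbazone series: bromo to iodo step

This account rests on a few compounds, and the source may have more. Where it says the series, first, only, none or still open, it means among the compounds named here.

Measured so far in a functional assay on the whole organism for inhibition, with Lemna aequinoctialis as the target, tested at 1000 ug/mL; on this read-out lower numbers stand for less inhibition of growth and higher numbers for more inhibition of growth at the one concentration tested:
Compound 1 `CCCCCCNC(=S)N/N=C1\C(=O)Nc2ccc([N+](=O)[O-])cc21` gives 60%.
Compound 2 `COc1ccc(NC(=S)N/N=C2\C(=O)Nc3ccc([N+](=O)[O-])cc32)cc1` gives 25%.
Compound 3 `O=C1Nc2ccc([N+](=O)[O-])cc2/C1=N/NC(=S)Nc1ccc(Br)cc1` gives 20%.

Compound 3 sits at the low end of the three values in this assay; its gap to compound 2 lies within the scatter, while its gap to compound 1 lies beyond it. The two large steps in the set, a number 35 percentage points lower from compound 1 to compound 2 (beyond the scatter) and a number 40 percentage points lower from compound 1 to compound 3 (beyond the scatter), both follow the exchange of the hexyl chain for a para-substituted phenyl on the amide-type nitrogen, not a change on the ring itself. Within the data shown here, the only step that touches the ring substituent is a number 5 percentage points lower from compound 2 to compound 3 (within the scatter), which stays within the scatter.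

Compound 4 `O=C1Nc2ccc([N+](=O)[O-])cc2/C1=N/NC(=S)Nc1ccc(I)cc1` differs from compound 3 by iodo in place of bromo on an aromatic carbon. No halogen-to-halogen exchange has been measured in this series, so the closest comparison remains the methoxy-to-bromo step, which moved nothing beyond the scatter. On that basis the expected change a number 2 percentage points higher from compound 3 to compound 4 (within the scatter) from compound 3 to compound 4 in this assay is none beyond the scatter. Compound 4 is therefore estimated at 22% in this assay, with a range from 5% to 40%.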

Compound 4, percent growth inhibition at one concentration: 25%
For compound 4 the middle estimate is 3 percentage points below the measured one; measured number inside the range.
By their numbers in this assay, from the lowest: compounds 3, 2 and 4 (each within the scatter of the next); then compound 1.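

Working notes on the series: in this assay the first exchange of one halogen for another on the aromatic carbon para to a large group gives a number 5 percentage points higher from compound 3 to compound 4 (within the scatter) and leaves iodo and bromo indistinguishable at this place, while iodo in place of methoxy gives no change at the digits printed from compound 2 to compound 4 (within the scatter) and so adds a third substituent that cannot be told apart from the other two. The large step away from the hexyl chain now holds for a third aryl group, since 4-iodophenyl in place of hexyl gives a number 35 percentage points lower from compound 1 to compound 4 (beyond the scatter) and compounds 2, 3 and 4 all stand apart from compound 1 in the same direction. Nothing measured here accounts for either the flat response at the ring substituent or the step from the chain to the aryl group.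

Still open, on these data alone, is whether an amine or a carboxylic acid on the same aromatic carbon would move the number beyond the scatter, and whether a butyl or octyl chain would stay near compound 1 at 60% in this assay. Because the read-out comes from a single concentration, the order of these compounds at other concentrations also remains open.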